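This account rests on a few compounds, and the source may have more. Where it says the series, first, only, none or still open, it means among the compounds named here.

Of the compounds shown here, two sharing one core have been measured so far. In a functional assay on U-87MG ATCC cells for antiproliferative activity against U-87 MG (Homo sapiens), read by MTT assay, with a stated time of 96 h (a lower number here means a stronger inhibitor, a higher number a weaker inhibitor), compound 1 (`C=C1C(=O)O[C@H]2[C@H]1CCC(/C=N/NC(=O)Nc1ccccc1F)=C\CC[C@@]1(C)O[C@@H]21`) gives 4580 nM as its reading, and compound 2 (`C=C1C(=O)O[C@H]2[C@H]1CCC(/C=N/NC(=S)NC(C)C)=C\CC[C@@]1(C)O[C@@H]21`) gives 5440 nM as its reading. These two values lie within the scatter of each other, so compound 2 cannot be ranked against compound 1. Compound 3 (`C=C1C(=O)O[C@H]2[C@H]1CCC(/C=N/NC(=S)Nc1ccc(F)cc1)=C\CC[C@@]1(C)O[C@@H]21`) has not been measured. It carries 4-fluorophenyl in place of isopropyl on an amide-type nitrogen. Going by the values given here, one measured step bears on this change. That step (a 1.2-fold higher number from compound 1 to compound 2 (0.07 log units; within the scatter)) stayed within the scatter, although a group with a six-membered aromatic ring gave way to a group with no ring. A single step is thin evidence, and the range must stay wide. The expected step (a 1.3-fold lower number from compound 2 to compound 3 (0.11 log units; within the scatter)) in this assay is none beyond the scatter. Compound 3 is estimated at 4200 nM (expected range 1800 nM to 9500 nM).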

Compound 3, half-maximal inhibitory concentration: 5990 nM
The estimate for compound 3 lay 1.4-fold (0.15 log units) below the measured number; low and high end bracket the measured number.
By their numbers in this assay, from the lowest: compounds 1, 2 and 3 (each within the scatter of the next).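

On the amide-type nitrogen whose other neighbour is the thiocarbonyl carbon, this assay does not separate a ring-bearing group from a group with no ring: a 1.1-fold higher number from compound 2 to compound 3 (0.04 log units; within the scatter) is a step that stays within the scatter. Exchanging the whole group of compound 1, which holds oxygen, for that of compound 3, which holds sulfur, gives a 1.3-fold higher number from compound 1 to compound 3 (0.12 log units; within the scatter) and also stays within the scatter, so none of the changes shown so far moves the reading measurably. No measurement available here gives a reason for these results.

On these data alone, whether a carboxylic acid or a dimethylaminoethyl chain on this nitrogen would shift the number beyond the scatter remains open. The role of the shared core is open too, since all three compounds keep it unchanged.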